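Aryl-to-trifluoromethyl switch on the nitro-bearing core

The source may report more compounds than this note shows. Statements on the series, on what has been measured and on what is new or still open speak of the compounds shown alone.

Within the data shown here, compound 2 `COc1ccc(Cn2c(-c3ccc(C)cc3)c(-c3cc(C)cc(C)c3)c(=O)c3cc([N+](=O)[O-])ccc32)cc1` gives 28700 nM in an assay on isolated protein for inhibition of Intestinal-type alkaline phosphatase (Bos taurus), read by spectrophotometry, with stated times of 7 min and 15 min (on this read-out lower numbers stand for stronger inhibition and higher numbers for weaker inhibition), the highest of the two numbers so far; compound 1 `CCc1ccc(-c2c(-c3ccc(C)cc3)n(Cc3ccc(OC)cc3)c3ccc([N+](=O)[O-])cc3c2=O)cc1` gives 5750 nM in this assay. Among the measured compounds shown here, the only measured step, a 5.0-fold higher number from compound 1 to compound 2 (0.70 log units; beyond the scatter), exchanges one aryl group for another and is modest. Compound 3 `COc1ccc(Cn2c(-c3ccc(C)cc3)c(C(F)(F)F)c(=O)c3cc([N+](=O)[O-])ccc32)cc1` makes a different kind of change: trifluoromethyl in place of 3,5-dimethylphenyl on an aromatic carbon. For the measured compounds named here, no measured pair matches an aryl-to-trifluoromethyl swap, so its direction is unknown. Compound 3 is therefore expected near compound 2, with a wide span, the estimated step being a 1.2-fold higher number from compound 2 to compound 3 (0.09 log units; within the scatter). The estimate for compound 3 in this assay is 35000 nM, with a range from 7000 nM to 175000 nM.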

Compound 3, half-maximal inhibitory concentration: 4580 nM
Beside the measured number, compound 3's estimate is 7.6-fold (0.88 log units) above it; measured number below the stated range.
By their numbers in this assay, from the lowest: compounds 3 and 1 (each within the scatter of the next); then compound 2.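

On this aromatic carbon of the shared core, a ring is not needed to hold the number in this assay, since trifluoromethyl in place of 3,5-dimethylphenyl gives a 6.3-fold lower number from compound 2 to compound 3 (0.80 log units; beyond the scatter). Trifluoromethyl in place of 4-ethylphenyl gives a 1.3-fold lower number from compound 1 to compound 3 (0.10 log units; within the scatter), so among these three groups only 3,5-dimethylphenyl stands apart. No evidence on hand bears on the reason for these differences.

Going by these compounds, whether methyl, a nitrile or a carboxylic acid on this carbon stays near compound 3 remains open. So does whether the trifluoromethyl result holds when the 4-methylphenyl or 4-methoxybenzyl group is replaced.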